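Swapping the fluorophenyl amide of compound 1 for an oxolane amide

The source may report more compounds than this note shows. Statements on the series, on what has been measured and on what is new or still open speak of the compounds shown alone.

Measured so far:
compound 1, `Cc1cc(C(=O)Nc2cccc(F)c2)nn1Cc1cc(Cl)ccc1OCc1ccccc1`, 2.8 in a physicochemical assay for lipophilicity, at pH 7.4; on this read-out higher numbers stand for higher lipophilicity and lower numbers for lower lipophilicity
compound 2, `Cc1cc(C(=O)Nc2ccccn2)nn1Cc1cc(Cl)ccc1OCc1ccccc1`, > 3.7 in this assay

For the measured compounds named here, compound 1 is the only compound with a number in this assay; compound 2 reports a limit of the assay, (the limit of > 3.7 in this assay, at which 1 of the 2 values shown sits). Compound 3, `Cc1cc(NC(=O)C2CCOC2)nn1Cc1cc(Cl)ccc1OCc1ccccc1`, has not been measured. It differs from compound 1 in one place: ((oxolan-3-yl)carbonyl)amino in place of (3-fluorophenyl)carbamoyl on an aromatic carbon. Going by the values given here, the one measured step, a number at least 0.90 log units higher from compound 1 to compound 2 (beyond the scatter), concerns a different change and does not bear on this one, so the expectation rests on the structural change alone. Compound 3 is expected to sit lower, a number 1.20 log units lower from compound 1 to compound 3 (beyond the scatter). Compound 3 is estimated at 1.6, between 1 and 2.3.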

Compound 3, distribution coefficient: > 3.7
Compound 3 gave a limit, no number; the forecaster's own chance of this, stated with the estimate: 5%; middle value at least 2.10 log units away from the limit.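

In this assay, ((oxolan-3-yl)carbonyl)amino in place of (3-fluorophenyl)carbamoyl on this aromatic carbon gives a number at least 0.90 log units higher from compound 1 to compound 3 (beyond the scatter), so the read-out does not depend on keeping the six-membered aromatic ring of carbon only. Compound 3 reports a limit rather than a number, as does compound 2: the limit of > 3.7 in this assay, at which 2 of the 3 values shown sit. The step between compound 2 and compound 3 therefore cannot be read.

From the compounds shown here alone, how far compound 3 lies past that limit remains open, as does whether a carboxylic acid or an amine on this aromatic carbon would give a readable number.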